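Acid dissociation across a three-compound aminoquinoline set

A few compounds are considered here, and "the series" means these few. Any claim that something is new, unique, unknown or untested is made for them only; others in the source may bear on it.

Measured so far:
compound 1 `COc1ccccc1Oc1ccc2c(NCCCNCc3ccco3)ccnc2c1` — 9.28
compound 2 `c1ccc(-c2ccc3c(NCCCNCc4ccco4)ccnc3c2)cc1` — 9.47
compound 3 `COc1cccc(CNCCCNc2ccnc3cc(-c4ccccc4)ccc23)c1O` — 9.47

In a physicochemical assay for acid dissociation, compound 2 gives 9.47 and compound 3 gives 9.47; the step of no change at the digits printed from compound 2 to compound 3 (within the scatter) comes with 2-hydroxy-3-methoxyphenyl in place of furan-2-yl on a saturated chain carbon bound to an amine nitrogen. Compound 1 differs from compound 2 by 2-methoxyphenoxy in place of phenyl on an aromatic carbon, giving the step of a number 0.19 log units lower from compound 2 to compound 1 (within the scatter).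

Compound 4 `COc1ccccc1Oc1ccc2c(NCCCNCc3cccc(OC)c3O)ccnc2c1` is not yet measured. It differs from compound 3 by 2-methoxyphenoxy in place of phenyl on an aromatic carbon, the same change as that from compound 2 to compound 1, and the cores of compound 3 and compound 2 differ as described by 2-hydroxy-3-methoxyphenyl in place of furan-2-yl on a saturated chain carbon bound to an amine nitrogen. Because a number 0.19 log units lower from compound 2 to compound 1 (within the scatter), a step of similar size, a number 0.19 log units lower from compound 3 to compound 4 (within the scatter), is expected here. Compound 4 is therefore estimated at 9.28 in this assay, with a range of 8.98 to 9.58.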

Compound 4, acid dissociation constant: 9.28
Compound 4: the middle estimate sits on the measured number at the digits printed; the range from low to high includes it.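

Notes on the series: in this assay, 2-methoxyphenoxy in place of phenyl gives the same reading on two cores (a number 0.19 log units lower from compound 3 to compound 4 (within the scatter); a number 0.19 log units lower from compound 2 to compound 1 (within the scatter)), and 2-hydroxy-3-methoxyphenyl in place of furan-2-yl on the 2-methoxyphenoxy core gives (no change at the digits printed from compound 1 to compound 4 (within the scatter)). The change therefore carries from one core to the other with a step of matching size, but that step lies within the scatter, so this pair shows no real shift and rests on two cores only. Nothing available bears on what sets these numbers.

Still open, as far as these compounds go, is whether a carboxylic acid or an amine on that aromatic carbon would give a step beyond the scatter. From the compounds shown here alone, a longer chain on the shared core is equally open.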